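Aryl versus benzyl on the piperazine nitrogen: compound 4

This account rests on a few compounds, and the source may have more. Where it says the series, first, only, none or still open, it means among the compounds named here.

Three compounds of the series have a number in an assay on CHO cells for displacement of a labelled ligand from adenosine receptor A3 (Homo sapiens), read by scintillation counting, with a stated time of 45 min, tested at 1 uM, in the presence of a further agent that is not named here; a lower number here means less inhibition, a higher number more inhibition at the concentration tested (going by the name of the read-out). Compound 1 `CCCn1c(=O)[nH]c2nc(-c3ccc(S(=O)(=O)N4CCN(Cc5cccc(Br)c5)CC4)cc3)[nH]c2c1=O` gives 23% in this assay. Compound 2 `CCCn1c(=O)c2[nH]c(-c3ccc(S(=O)(=O)N4CCN(c5ccc(Cl)cc5)CC4)cc3)nc2n(C)c1=O` gives 39% in this assay, and compound 3 `CCCn1c(=O)[nH]c2nc(-c3ccc(S(=O)(=O)N4CCN(c5ccccc5)C(C)C4)cc3)[nH]c2c1=O` gives -2% in this assay. On these numbers compound 1 stands second highest of the three: compound 2 lies a step higher that is beyond the scatter, and compound 3 lies a step lower that is also beyond the scatter. No pair of these compounds differs in one place only, so none of the gaps between them can be tied to a single change.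

Compound 4 `CCCn1c(=O)[nH]c2nc(-c3ccc(S(=O)(=O)N4CCN(c5ccccc5Cl)CC4)cc3)[nH]c2c1=O` has not yet been measured in this assay. Relative to compound 1 it carries 2-chlorophenyl in place of 3-bromobenzyl on an amine nitrogen in a ring. The two measured compounds that carry an aryl group on the amine nitrogen in a ring, compound 2 and compound 3, sit on either side of compound 1, so the move from a benzyl group to an aryl group gives no clear direction here.

For compound 4 the expected step is a number 2 percentage points higher from compound 1 to compound 4 (within the scatter), which is expected to stay within the scatter. The estimate for compound 4 in this assay is 25%, with a range from 5% to 45%.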

Compound 4, a percentage reported as inhibition, at one concentration (the size of the read-out at that concentration, not a potency): 32%
Compound 4: middle estimate off by 7 percentage points, on the low side; the measured number falls inside the stated range.
By their numbers in this assay, from the lowest: compound 3; then compounds 1, 4 and 2 (each within the scatter of the next, the first and the last beyond it).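

In this assay, for the compounds shown here, 2-chlorophenyl in place of 3-bromobenzyl on the amine nitrogen in the ring gives a number 9 percentage points higher from compound 1 to compound 4 (within the scatter) and is the first step that can be tied to one place, showing that this position accepts either group with no difference beyond the usual scatter. The swap replaces the whole group at once, so the removal of the benzyl carbon, the change of halogen and any change in where the halogen sits on the aromatic ring cannot be separated, and opposing contributions remain possible. No measurement bears on what lies behind this result.

Going by these compounds, what a longer chain on this nitrogen, or an amine or a carboxylic acid on the aromatic ring in place of the halogen, would do to the inhibition in this assay remains open. On these data alone, compound 2 and compound 3 each differ from compound 4 in more than one place, so it also remains open how much of the spread across the series comes from this position and how much from changes elsewhere in the structure.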